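The source may hold more compounds than are shown below. What is called first, only, known or untested is meant among the compounds shown, and "the series" means these compounds.

Going by the values given here, in a physicochemical assay for solubility, in phosphate buffer, at pH 7.4 (a lower number here means a less soluble compound, a higher number a more soluble compound), compound 1 `OCC1CCN(c2nccnc2OC2CN(c3ccc4ccccc4n3)C2)C1` gives 167000 nM, the lowest of the two numbers measured so far. Among the compounds with values here, its only measured neighbour is compound 2 `CN(C)C1CCN(c2nccnc2OC2CN(c3ccc4ccccc4n3)C2)CC1`, which in this assay gives 500000 nM; that step is a 3.0-fold higher number from compound 1 to compound 2 (0.48 log units; beyond the scatter). Compound 3 `CS(=O)(=O)N1CCC(c2nccnc2OC2CN(c3ccc4ccccc4n3)C2)CC1` has not yet been measured. It differs from compound 1 in one place: 1-(methylsulfonyl)piperidin-4-yl in place of 3-(hydroxymethyl)pyrrolidin-1-yl on an aromatic carbon. Within the data shown here, the one measured step, from compound 1 to compound 2, exchanges the same group on the shared core for a different ring and so bears only loosely on this change; the entering group in compound 3 is not the one that gave the higher number in compound 2. Among the measured compounds shown here, with no closer step to lean on, the expectation for compound 3 is a modest drop, a 3.3-fold lower number from compound 1 to compound 3 (0.52 log units; beyond the scatter), and compound 3 is estimated at 50000 nM, with a range from 15000 nM to 170000 nM.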

Compound 3, solubility: 181000 nM
For compound 3 the middle estimate is 3.6-fold (0.56 log units) below the measured one; measured number above the stated range.
By their numbers in this assay, from the lowest: compounds 1 and 3 (each within the scatter of the next); then compound 2.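

In this assay, 1-(methylsulfonyl)piperidin-4-yl in place of 3-(hydroxymethyl)pyrrolidin-1-yl gives a 1.1-fold higher number from compound 1 to compound 3 (0.03 log units; within the scatter), so at this position a group with more heavy atoms, a six-membered ring and no hydrogen-bond donor reads the same as the original group. Set against the 4-(dimethylamino)piperidin-1-yl group, the same entering group gives a 2.8-fold lower number from compound 2 to compound 3 (0.44 log units; beyond the scatter), which leaves compound 2 apart from the other two compounds in this assay. No measured evidence is available to explain these numbers.

The compounds shown leave open whether the higher number of compound 2 goes with its dimethylamino group or with the rest of that substituent. On these data alone, how a primary amine or a carboxylic acid at this position would read in this assay also remains open.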